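From an Amide to an Ester: Compound 3 to Compound 4

A few compounds are considered here, and "the series" means these few. Any claim that something is new, unique, unknown or untested is made for them only; others in the source may bear on it.

Three compounds have so far been measured in a functional assay on the whole organism for inhibition, with Brassica rapa subsp. chinensis as the target, with a stated time of 3 days, tested at 100 ppm; a lower number here means less inhibition of growth, a higher number more inhibition of growth at the concentration tested:

compound 1 `C=CCNC(=O)/C=C/c1ccccc1` — 64%
compound 2 `CCC(C)NC(=O)/C=C/c1ccccc1` — 77%
compound 3 `CCCNC(=O)/C=C/c1ccccc1` — 63%

Compound 3 stands lowest of the three numbers. Compound 1 lies within the scatter of it, and only compound 2 sits clearly apart, as shown by a number 14 percentage points lower from compound 2 to compound 3 (beyond the scatter). All three measured steps concern the chain on the amide-type nitrogen: a number 13 percentage points higher from compound 1 to compound 2 (beyond the scatter), a number 1 percentage points lower from compound 1 to compound 3 (within the scatter) and the step already named. Each of them is modest or within the scatter.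

Compound 4 `CCCCOC(=O)/C=C/c1ccccc1` differs from compound 3 at another place: butoxy in place of propylamino on a carbonyl carbon. Among the compounds with values here, none of the measured steps touches the carbonyl carbon or exchanges the amide-type nitrogen for an oxygen, so none bears directly on this change. They show only that altering a carbon or two on the chain shifted this assay by a modest amount at most, and that is the only footing available. For compound 4 a step of a number 3 percentage points lower from compound 3 to compound 4 (within the scatter) is therefore expected, with no confident direction and a wide margin. Compound 4 is estimated at 60%, with a range from 40% to 80%.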

Compound 4, percent growth inhibition at one concentration: 0%
The estimate for compound 4 lay 60 percentage points above the measured number; the measured number lies below the stated range.
By their numbers in this assay, from the lowest: compound 4; then compounds 3 and 1 (each within the scatter of the next); then compound 2.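

In this assay, within the data shown here, the carbonyl carbon proved a far more sensitive place than the chain on the amide-type nitrogen, with a large step (a number 63 percentage points lower from compound 3 to compound 4 (beyond the scatter)) where the earlier steps were modest or within the scatter. The same large loss appears whichever of the three amino groups gives way to butoxy (a number 77 percentage points lower from compound 2 to compound 4 (beyond the scatter); a number 64 percentage points lower from compound 1 to compound 4 (beyond the scatter)), so the differences among those chains offered no protection against this exchange. The change swaps propylamino, which has a hydrogen-bond donor, for butoxy, which has none, and it also alters the atom on the carbonyl carbon and the chain length together, while nothing available bears on why the growth inhibition disappears.

The compounds shown do not separate the exchange of nitrogen for oxygen from the change in chain, a question that propoxy or butylamino on the same carbonyl carbon would address directly. They also leave open whether other groups there, such as a carboxylic acid or a tertiary amide, would retain any inhibition of growth.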